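Replacing pyrrolidin-1-yl on a thiocarbonyl carbon

The source may hold more compounds than are shown below. What is called first, only, known or untested is meant among the compounds shown, and "the series" means these compounds.

Measured in a functional assay on HCT-116 cells (Homo sapiens) for inhibition, read by CCK-8 assay, with a stated time of 48 h; on this read-out lower numbers stand for stronger inhibition and higher numbers for weaker inhibition:
compound 1 `COc1ccc(CN(C(=O)CSC(=S)N2CCOCC2)c2cc(OC)c(OC)c(OC)c2)cc1`: 4130 nM
compound 2 `COc1ccc(CN(C(=O)CSC(=S)N2CCCC2)c2cc(OC)c(OC)c(OC)c2)cc1`: 4970 nM

Compound 2, at 4970 nM, cannot be told apart from compound 1, at 4130 nM, so the two stand together on the numbers available. Compound 3 `COc1ccc(CN(C(=O)CSC(=S)N2CCc3cc(OC)ccc32)c2cc(OC)c(OC)c(OC)c2)cc1` carries 5-methoxy-2,3-dihydro-1H-indol-1-yl in place of pyrrolidin-1-yl on a thiocarbonyl carbon. Going by the values given here, only one measured step bears on this place. That step, a 1.2-fold higher number from compound 1 to compound 2 (0.08 log units; within the scatter), exchanged morpholin-4-yl for pyrrolidin-1-yl and stayed within the scatter. It offers limited guidance, since neither measured compound has an aromatic ring in the group at this place. The change to compound 3 therefore goes beyond what has been tested, and any forecast in this assay is uncertain. A move to a lower number is expected, though only tentatively, and the range must stay wide. The expected change is a 3.3-fold lower number from compound 2 to compound 3 (0.52 log units; beyond the scatter). For compound 3 the estimated value is 1500 nM, with an expected range from 200 nM to 6000 nM.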

Compound 3, half-maximal inhibitory concentration: 9810 nM
The estimate for compound 3 lay 6.5-fold (0.82 log units) below the measured number; the whole stated range lies below it.
By their numbers in this assay, from the lowest: compounds 1, 2 and 3 (each within the scatter of the next, the first and the last beyond it).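

In this assay, the group on a thiocarbonyl carbon now includes a six-membered aromatic ring of carbon only, and this larger group brings no gain. Going by these compounds alone, exchanging pyrrolidin-1-yl for 5-methoxy-2,3-dihydro-1H-indol-1-yl gives a 2.0-fold higher number from compound 2 to compound 3 (0.30 log units; within the scatter), so those two compounds cannot be separated, while exchanging morpholin-4-yl for the same group gives a 2.4-fold higher number from compound 1 to compound 3 (0.38 log units; beyond the scatter), the first modest step at this place to pass the scatter. None of the three steps at this place has produced a lower number beyond the scatter, and no measurement is available to explain the outcome.

The compounds shown leave open whether plain 2,3-dihydro-1H-indol-1-yl would read differently from its 5-methoxy counterpart, which would separate the contribution of the methoxy group from that of the aromatic ring. They also leave open how an open-chain amine such as dimethylamino or diethylamino, or a piperazin-1-yl group with its free amine, would read at this place on the shared core.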